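The source may report more compounds than this note shows. Statements on the series, on what has been measured and on what is new or still open speak of the compounds shown alone.

Measured so far in a functional assay (uterus) for inhibition, with Rattus norvegicus as the target; a lower number here means that less compound is needed, a higher number that more compound is needed for the effect:

- Compound 1 `ClCc1cn2ccncc2n1`: 1.4 nM
- Compound 2 `OCc1cn2ccncc2n1`: 2.7 nM

Compound 2, at 2.7 nM, cannot be separated from compound 1, since a 1.9-fold higher number from compound 1 to compound 2 (0.29 log units; within the scatter) stays within the scatter. The two compounds therefore stand together on the numbers available.

The next compound is compound 3 `NC(=O)c1cn2ccncc2n1`, still to be measured in this assay. The change is carbamoyl in place of hydroxymethyl on an aromatic carbon.

Going by the values given here, only one measured step offers any guide, and it is indirect. In a 1.9-fold higher number from compound 1 to compound 2 (0.29 log units; within the scatter), the exchange of chloro for hydroxy on the saturated chain carbon left the number within the scatter. Among the compounds with values here, no measured compound carries a carbamoyl, so the data do not test this change directly.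

On that thin basis, only a small move toward a higher number is expected, with no clear departure from the scatter. The expected step is a 1.5-fold higher number from compound 2 to compound 3 (0.17 log units; within the scatter). The range is kept wide for that reason. For compound 3 the estimate is 4 nM, with the value expected between 1 nM and 20 nM.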

Compound 3, concentration for half-maximal effect: 1.5 nM
The estimate for compound 3 lay 2.7-fold (0.43 log units) above the measured number, within the range that was stated.
By their numbers in this assay, from the lowest: compounds 1, 3 and 2 (each within the scatter of the next).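

In this assay, going by these compounds alone, the earlier compounds had varied only the group on the saturated chain carbon, and compound 3 is the first to replace that chain carbon with a carbonyl carbon on this aromatic carbon of the five-membered ring, with a 1.8-fold lower number from compound 2 to compound 3 (0.26 log units; within the scatter) as the outcome of the exchange. Set against the chloromethyl group, the carbamoyl group gives the same picture, with a 1.1-fold higher number from compound 1 to compound 3 (0.03 log units; within the scatter) as the direct comparison between those two compounds. Chloromethyl, hydroxymethyl and carbamoyl therefore cannot be told apart at this position, so a double bond outside aromatic rings can stand here without the number leaving the scatter, and no available evidence bears on why these three groups read alike.

The compounds shown leave open whether a carboxylic acid, an amine or a longer chain on this aromatic carbon would also stay within the scatter or would finally separate from these three. They also leave open what a methyl group on the carbamoyl nitrogen would do, in place of the amide hydrogen.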